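From azido to methylsulfonyl in a cell toxicity test

The compounds below may be only part of what the source reports. "The series", "measured", "known", "first", "only" and "open" are said of these compounds alone.

In an ADME assay on L1210/0 cells (Mus musculus) for cytotoxicity, with a stated time of 48 h (on this read-out higher numbers stand for weaker inhibition and lower numbers for stronger inhibition), compound 1 (`COc1ccc(-c2ncnc3c2ncn3C[C@@H]2C[C@H](CO)c3ccccc32)cc1`) gives 17600 nM. Compound 2 (`[N-]=[N+]=NCc1cn([C@H]2C[C@H](O)[C@@H](CO)O2)c(=O)[nH]c1=O`) gives 124000 nM, the higher of the two numbers and thus the weaker inhibition, a gap beyond the usual scatter. Compound 3 (`CS(=O)(=O)Cc1cn([C@H]2C[C@H](O)[C@@H](CO)O2)c(=O)[nH]c1=O`) has methylsulfonyl in place of azido on a saturated chain carbon bound to an aromatic carbon. Among the measured compounds shown here, no measured pair shows what this kind of change does. A modest move towards weaker inhibition is expected, a 1.6-fold higher number from compound 2 to compound 3 (0.21 log units; within the scatter). The estimate for compound 3 is 200000 nM, with an expected range from 70000 nM to 600000 nM.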

Compound 3, half-maximal inhibitory concentration: > 200000 nM
Compound 3 was reported as a limit; the forecaster's own chance of this, stated with the estimate: 30%; the middle value sits exactly at the limit.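

Among the compounds shown here, this is the first measured pair for this position: methylsulfonyl in place of azido on a saturated chain carbon bound to an aromatic carbon gives an at least 1.6-fold higher number from compound 2 to compound 3 (0.20 log units; that floor lies within the scatter). The reading for compound 3 is a limit of the assay, not a number: the limit of > 200000 nM in this assay, at which 1 of the 3 values shown sits. From the compounds shown here alone, the pair therefore shows no sign that methylsulfonyl gives stronger inhibition than azido at this place, but only a floor for the step is known, so its true size remains unknown.

Going by these compounds, whether an amine or a carboxylic acid at this place would give a measurable number remains open. The compounds shown also do not reveal how this change would behave on the core of compound 1.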